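Shrinking the para group on the benzyl arm of an EP4 antagonist

This account rests on a few compounds, and the source may have more. Where it says the series, first, only, none or still open, it means among the compounds named here.

Compound 1, `C[C@H](NC(=O)c1cccc2c1N(Cc1ccc(Cl)c(Cl)c1)CC2)c1ccc(C(=O)O)cc1`: 1.1 nM
Compound 2, `C[C@H](NC(=O)c1cccc2c1N(Cc1ccc(F)cc1)CC2)c1ccc(C(=O)O)cc1`: 6.2 nM
Compound 3, `C[C@H](NC(=O)c1cccc2c1N(Cc1ccc(C(C)(C)C)cc1)CC2)c1ccc(C(=O)O)cc1`: 114 nM

In a functional assay on HEK293 cells for antagonist activity at prostaglandin E2 receptor EP4 subtype (Homo sapiens), read by scintillation proximity assay and cAMP accumulation (a higher number here means a weaker inhibitor, a lower number a stronger inhibitor), compound 3 has the highest number of the three, and its steps to the others are beyond the scatter: a 100-fold higher number from compound 1 to compound 3 (2.02 log units; beyond the scatter) and an 18-fold higher number from compound 2 to compound 3 (1.26 log units; beyond the scatter). Compound 4, `Cc1ccc(CN2CCc3cccc(C(=O)N[C@@H](C)c4ccc(C(=O)O)cc4)c32)cc1`, differs from compound 3 in one place: methyl in place of tert-butyl on an aromatic carbon para to a large group. The step that bears on it is the one where tert-butyl replaced fluoro, an 18-fold higher number from compound 2 to compound 3 (1.26 log units; beyond the scatter), a large rise. Undoing part of that change is expected to lower the number again, a 4.6-fold lower number from compound 3 to compound 4 (0.66 log units; beyond the scatter), though likely not all the way to compound 2. The estimate for compound 4 in this assay is 25 nM, with a range from 8 nM to 80 nM.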

Compound 4, half-maximal inhibitory concentration: 5.8 nM
Compound 4: the middle estimate sits 4.3-fold (0.63 log units) above what was measured, and the stated range ends above it.
By their numbers in this assay, from the lowest: compound 1; then compounds 4 and 2 (each within the scatter of the next); then compound 3.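

Cutting tert-butyl down to methyl undoes the whole rise (a 20-fold lower number from compound 3 to compound 4 (1.29 log units; beyond the scatter)), and methyl and fluoro cannot be told apart at this aromatic carbon (a 1.1-fold lower number from compound 2 to compound 4 (0.03 log units; within the scatter)), so of these three groups only tert-butyl stands out. The 3,4-dichlorophenyl arm of compound 1 still gives the lower number (a 5.3-fold higher number from compound 1 to compound 4 (0.72 log units; beyond the scatter)). Nothing at hand explains these differences.

Ethyl or isopropyl in this place could show where between methyl and tert-butyl the number starts to climb. A single chlorine here would show whether one halogen alone accounts for the lower number of compound 1.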